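The source may report more compounds than this note shows. Statements on the series, on what has been measured and on what is new or still open speak of the compounds shown alone.

Compound 1 `CCCC(=O)Nc1ccc2[nH]cc(C3CCN(C)CC3)c2n1` binds in an assay for binding affinity to 5-hydroxytryptamine receptor 1F (Homo sapiens), read by radioligand binding (on this read-out lower numbers stand for stronger inhibition and higher numbers for weaker inhibition), with 6.9 nM, and compound 2 `CN1CCC(c2c[nH]c3ccc(NC(=O)Nc4ccc(F)cc4)nc23)CC1` gives 11 nM; the step of a 1.6-fold higher number from compound 1 to compound 2 (0.20 log units; within the scatter) lies within the scatter. Compound 3 `CCN1CCC(c2c[nH]c3ccc(NC(=O)c4ccc(F)cc4)nc23)CC1`, measured at 170 nM, has the highest number of the three, well beyond the scatter from compound 2 and from compound 1. Compound 4 `O=C(Nc1ccc2[nH]cc(C3CCNCC3)c2n1)c1ccc(F)cc1` differs from compound 3 only in hydrogen in place of ethyl on an amine nitrogen in a ring. For the measured compounds named here, none of the measured steps touches the substituent on this ring nitrogen, so no step bears directly on the change; the expectation therefore rests on compound 3 alone, with a wide margin. The estimated step of a 1.7-fold lower number from compound 3 to compound 4 (0.23 log units; within the scatter) is taken as roughly no change beyond the scatter. Compound 4 is expected to give about 100 nM, within 25 nM to 400 nM.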

Compound 4, inhibition constant: 9.5 nM
Compound 4: middle estimate off by 11-fold (1.02 log units), on the high side; measured number outside the range, below it.
By their numbers in this assay, from the lowest: compounds 1, 4 and 2 (each within the scatter of the next); then compound 3.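

In this assay, the group on the ring nitrogen clearly matters: hydrogen in place of ethyl gives an 18-fold lower number from compound 3 to compound 4 (1.25 log units; beyond the scatter), so removing just two carbons from this position produces a large change. For the compounds shown here, this is the first measured step at this nitrogen, and it shows that the position is not indifferent to such a small edit. Nothing available explains why so small a change has so large an effect. Open, going by these compounds, is what an acetyl group or a longer chain such as propyl on this ring nitrogen would give, and whether the step holds when the carbonyl carbon bears another group.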